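The compounds below may be only part of what the source reports. "The series", "measured", "known", "first", "only" and "open" are said of these compounds alone.

Values measured in an ADME assay on Caco-2 cells (Homo sapiens) for permeability, in the apical to basolateral direction; a higher number here means that the compound crosses the layer faster, a lower number that the compound crosses the layer more slowly:
- compound 1 `CC(=O)N1CCN(c2cccc(-c3cc(-c4cnc(Cl)n4C)c4c(N)ncnn34)c2)C(=O)C1(C)C`: < 36 nm/s (a limit of the assay)
- compound 2 `COc1ccc(-c2cc(Cl)c3c(N)ncnn23)cc1N1CCN(C(C)=O)C(C)(C)C1=O`: 170 nm/s

Within the data shown here, only one true number is available in this assay, and it belongs to compound 2, at 170 nm/s. Compound 1 gives only a limit, < 36 nm/s, and no number.

Compound 3 `CC(=O)N1CCN(c2cc(-c3cc(Cl)c4c(N)ncnn34)ccc2C(C)O)C(=O)C1(C)C` has not yet been measured in this assay. It differs from compound 2 in a single place: 1-hydroxyethyl in place of methoxy on an aromatic carbon. Here, 1-hydroxyethyl stands in place of methoxy on an aromatic carbon of a six-membered aromatic ring of carbon only, ortho to a large group and para to a large group.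

Among the measured compounds shown here, no measured pair differs in only one place, so the data hold no direct precedent for this exchange. The expectation therefore starts from compound 2 at 170 nm/s and is a modest fall, close to the edge of the usual scatter. The expected change is a 2.0-fold lower number from compound 2 to compound 3 (0.30 log units; within the scatter). Compound 3 is estimated at 85 nm/s, with an expected range of 40 nm/s to 170 nm/s.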

Compound 3, apparent permeability: 31 nm/s
Estimate against measurement, compound 3: 2.7-fold (0.44 log units) above, and the stated range ends above it.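

In this assay, putting 1-hydroxyethyl in place of methoxy on this aromatic carbon, ortho to a large group and para to a large group, gives a 5.5-fold lower number from compound 2 to compound 3 (0.74 log units; beyond the scatter), a step beyond the usual scatter. Among these compounds, this is the first sign that the number in this assay responds to the group at this position, which compound 2 alone, or compound 1 with its different substitution, could not show. The entering group carries a hydrogen-bond donor that methoxy lacks, as well as one more carbon, and this single step cannot separate the two differences; the number for compound 3 also lies in the low range of the assay, where compound 1 gives only a limit: the limit of < 36 nm/s in this assay, at which 1 of the 3 values shown sits.

The compounds shown leave open whether the lower number goes with the hydroxyl group or with the larger carbon chain, which 1-methoxyethyl or hydroxymethyl at the same position would help to tell apart. They also leave open whether the same exchange would have a comparable effect on a compound other than compound 2.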